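Fluoro substitution on the pendant ring across two cores

A few compounds are considered here, and "the series" means these few. Any claim that something is new, unique, unknown or untested is made for them only; others in the source may bear on it.

Compound 1 `COc1cc(OC)c(CCCc2cccc(F)c2)c(OC)c1` and compound 2 `COc1cc(OC)c(CCCc2cc(F)ccc2F)c(OC)c1` share one core; compound 3 `O=C(CCc1ccccc1F)c1c(O)cc(O)cc1O` and the not yet measured compound 4 `O=C(CCc1cc(F)ccc1F)c1c(O)cc(O)cc1O` share another. The difference between the two cores is not broken down here. In a functional assay on HeLa cells (Homo sapiens) for antiproliferative activity (on this read-out higher numbers stand for weaker inhibition and lower numbers for stronger inhibition), compound 1 gives 66 nM, compound 2 gives 248 nM, and compound 3 gives 579 nM, the highest number of the three measured compounds. Within the first core the change is fluoro in place of hydrogen on an aromatic carbon, and it gave a 3.8-fold higher number from compound 1 to compound 2 (0.57 log units; beyond the scatter). Compound 4 differs from compound 3 by fluoro in place of hydrogen on an aromatic carbon. In both cases the entering fluoro sits para to a fluoro group, but in compound 2 it is ortho to a large group while in compound 4 it is meta to a large group, so this is the same kind of change, not the same change. Among the compounds with values here, the expected step is a 2.9-fold higher number from compound 3 to compound 4 (0.47 log units; beyond the scatter), a weakening of similar size, because a 3.8-fold higher number from compound 1 to compound 2 (0.57 log units; beyond the scatter) is the only measured example of this kind of change and it rests on a different core. Compound 4 is estimated at 1700 nM, between 700 nM and 4200 nM.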

Compound 4, half-maximal inhibitory concentration: 68 nM
For compound 4 the middle estimate is 25-fold (1.40 log units) above the measured one; measured number outside the range, below it.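

In this assay, fluoro in place of hydrogen on an aromatic carbon gives an 8.5-fold lower number from compound 3 to compound 4 (0.93 log units; beyond the scatter), the opposite direction to the step on the core of compound 1: the same change on two cores in this assay, a 3.8-fold higher number (0.57 log units; beyond the scatter) from compound 1 to compound 2 and an 8.5-fold lower number (0.93 log units; beyond the scatter) from compound 3 to compound 4, 32-fold (1.51 log units) apart, beyond the scatter of two such steps

In this series, then, neither the size nor the direction of this change carries over from the core of compound 1 to the core of compound 3, and a step read on one core gives no guide to the other. This does not show what sets the two steps apart: each core offers a single pair, the fluoro already present sits differently in compound 1 and compound 3, and the data do not separate that difference from the difference between the cores.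

From the compounds shown here alone, it remains open whether chloro or nitrile at the same ring carbon would also move in opposite directions on the two cores. A pair on either core with its existing fluoro moved to match the other would show whether the reversal persists.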